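The source may hold more compounds than are shown below. What is called first, only, known or untested is meant among the compounds shown, and "the series" means these compounds.

In a functional assay on HT-29 cells (Homo sapiens) for antiproliferative activity, read by MTT assay, with a stated time of 24 h (on this read-out lower numbers stand for stronger inhibition and higher numbers for weaker inhibition), three compounds that share one core have been measured. Compound 1 `COc1ccc(C(=O)/C=C/c2ccc(F)cc2)c2c1C=CC(C)(C)O2`, with a 4-fluorophenyl group on the chain, gives > 10000 nM, which is a limit of the assay and not a number. Compound 2 `COc1ccc(C(=O)/C=C/c2cccc([N+](=O)[O-])c2)c2c1C=CC(C)(C)O2`, with a 3-nitrophenyl group, gives 4260 nM. Compound 3 `COc1ccc(C(=O)/C=C/c2ccsc2)c2c1C=CC(C)(C)O2`, with a thiophen-3-yl group, gives > 10000 nM, which is also a limit. Compound 3 therefore stands at the limit of > 10000 nM in this assay, at which 2 of the 3 values shown sit.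

Compound 4 `COc1ccc(C(=O)/C=C/c2cccs2)c2c1C=CC(C)(C)O2` has the same atoms joined differently: thiophen-2-yl in place of thiophen-3-yl on a double-bonded chain carbon bound to a double-bonded chain carbon. Going by the values given here, no measured step swaps one thiophene for the other, so the nearest guides are swaps at the same place. These gave an at least 2.3-fold lower number from compound 1 to compound 2 (0.37 log units; beyond the scatter) and an at least 2.3-fold higher number from compound 2 to compound 3 (0.37 log units; beyond the scatter), while the third swap gave a step that the two limits leave unreadable from compound 1 to compound 3. Only the 3-nitrophenyl group of compound 2 has given a number, and compound 4 does not carry it. A step beyond the scatter is therefore not expected, and another result at the limit is likely. The expected step is a number no higher from compound 3 to compound 4 (the limit leaves the size open). For compound 4 the estimated value is 10000 nM, with an expected range from 4000 nM to 25000 nM.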

Compound 4, half-maximal inhibitory concentration: > 10000 nM
Compound 4: a limit, no number; the forecaster's own chance of this, stated with the estimate: 60%; the middle value lies on the limit itself.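

In this assay compound 4 gives > 10000 nM, which is a limit of the assay and not a number, so changing thiophen-3-yl to thiophen-2-yl on this double-bonded chain carbon does not yield a measurable value. Going by these compounds alone, only one new step can be read, an at least 2.3-fold higher number from compound 2 to compound 4 (0.37 log units; beyond the scatter), and the steps that join two limits cannot be read. Of the groups tried at this place, the 3-nitrophenyl group of compound 2 remains the only one with a number, and the limit now holds for most of the set: the limit of > 10000 nM in this assay, at which 3 of the 4 values shown sit.

Going by these compounds, how far compound 1, compound 3 and compound 4 lie beyond the limit stays unknown, so whether the two thiophene groups differ at all cannot be told. Also open, on these data alone, is how a 3-aminophenyl or a 3-carboxyphenyl group would behave at this place on the chain.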